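A Halogen Swap on the Ring Nitrogen, Before Measurement

This account rests on a few compounds, and the source may have more. Where it says the series, first, only, none or still open, it means among the compounds named here.

Measured compounds:
Compound 1 `O=C(Nc1ccc(Oc2ccnc3[nH]ccc23)cc1)c1nn(-c2ccc(Cl)c(F)c2)ccc1=O` gives 5240 nM
Compound 2 `Cc1cc(=O)n(-c2cccc(F)c2)nc1C(=O)Nc1ccc(Oc2ncnc3[nH]ccc23)cc1` gives 3180 nM

Both compounds were tested in a functional assay on HepG2 cells (Homo sapiens) for cytotoxicity, read by MTT assay, with a stated time of 72 h; a lower number here means a stronger inhibitor, a higher number a weaker inhibitor. Compound 2 has the lowest of the two numbers, and its nearest neighbour, compound 1, sits a little higher, but that gap lies within the usual scatter of repeated measurements, so the two values cannot be ranked against each other with confidence. Going by the values given here, no step between two measured compounds that differ in only one place is available here, so there is no measured reference for the size of a single change.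

Compound 3 `Cc1cc(=O)n(-c2ccc(Br)cc2F)nc1C(=O)Nc1ccc(Oc2ncnc3[nH]ccc23)cc1` is the next compound to be measured in this assay. It differs from compound 2 by one change: 4-bromo-2-fluorophenyl in place of 3-fluorophenyl on an aromatic nitrogen. Among the compounds with values here, with only two values in hand, neither of them forming a single-point step, the effect of this change cannot be anchored to anything measured, and the expectation is a step of no more than the scatter, in either direction. For compound 3 the estimated value is 2600 nM, with a range from 900 nM to 7500 nM. This estimate means an expected step of a 1.2-fold lower number from compound 2 to compound 3 (0.09 log units; within the scatter).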

Compound 3, half-maximal inhibitory concentration: 3660 nM
Beside the measured number, compound 3's estimate is 1.4-fold (0.15 log units) below it; measured number inside the range.
By their numbers in this assay, from the lowest: compounds 2, 3 and 1 (each within the scatter of the next).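

Going by these compounds alone, the first comparison between measured compounds that differ in one place is now available: in this assay, 4-bromo-2-fluorophenyl in place of 3-fluorophenyl on the aromatic nitrogen gives a 1.2-fold higher number from compound 2 to compound 3 (0.06 log units; within the scatter), so the readout does not distinguish the two groups. At this position, then, a phenyl ring carrying both bromine and fluorine gives a value that cannot be told apart from that of a ring carrying fluorine alone, at least for this pair on this core. Nothing available here offers an explanation of this result at the molecular level.

The swap alters the ring in two ways at once, adding a bromine and placing the fluorine differently, so a 4-bromophenyl or a 2-fluorophenyl group would be needed to separate the two alterations, and either could still hide opposing contributions that happen to cancel in compound 3. Going by these compounds, it also remains open whether a group of a different kind on this nitrogen, such as a pyridine ring, a plain methyl or a chain ending in an amine or a carboxylic acid, would give a step beyond the scatter.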